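The source may report more compounds than this note shows. Statements on the series, on what has been measured and on what is new or still open speak of the compounds shown alone.

Compound 3 `N#CC1=C(N)Oc2c(N)cc3nc4ccccc4nc3c2C12C(=O)N(Cc1cnnn1-c1ccccc1Cl)c1ccccc12` gives 34400 nM in a functional assay on MCF7 cells (Homo sapiens) for antiproliferative activity, read by MTT assay, with a stated time of 48 h; on this read-out higher numbers stand for weaker inhibition and lower numbers for stronger inhibition. Compound 1 `N#CC1=C(N)Oc2c(c3nc4ccccc4nc3c3ccccc23)C12C(=O)N(Cc1cnnn1-c1ccc(Br)cc1)c1ccccc12` gives 36600 nM in this assay, a number that sits within the usual scatter of the value for compound 3. Compound 2 `COc1ccc(-n2nncc2CN2C(=O)C3(C(C#N)=C(N)Oc4c3c3nc5ccccc5nc3c3ccccc43)c3ccccc32)cc1` reaches only a limit of this assay, > 50000 nM. Compound 4 `Cc1cc(C)cc(-n2nncc2CN2C(=O)C3(C(C#N)=C(N)Oc4c(N)cc5nc6ccccc6nc5c43)c3ccccc32)c1` differs from compound 3 by 3,5-dimethylphenyl in place of 2-chlorophenyl on an aromatic nitrogen. Going by the values given here, the single measured step, an at least 1.3-fold higher number from compound 1 to compound 2 (0.13 log units; that floor lies within the scatter), also exchanges a group on the ring that stands on that aromatic nitrogen, and it ends at a limit (the limit of > 50000 nM in this assay, at which 1 of the 3 values shown sits), so only a floor within the scatter is known for it. No step beyond the scatter is therefore expected, with some risk that compound 4 also reaches the limit. Compound 4 is estimated at 40000 nM, between 18000 nM and 90000 nM, an expected step of a 1.2-fold higher number from compound 3 to compound 4 (0.07 log units; within the scatter).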

Compound 4, half-maximal inhibitory concentration: > 50000 nM
Compound 4: no number, only a limit; the forecaster's own chance of this, stated with the estimate: 35%; middle value at least 1.2-fold (0.09 log units) from the limit.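

In this assay, 3,5-dimethylphenyl in place of 2-chlorophenyl on the aromatic nitrogen gives an at least 1.4-fold higher number from compound 3 to compound 4 (0.16 log units; that floor lies within the scatter). Compound 4 stands at a limit, > 50000 nM, and not at a number. A change on this ring now ends at a limit on the core of compound 3 as well as on the core of compound 1, so the limit is no longer a single case: the limit of > 50000 nM in this assay, at which 2 of the 4 values shown sit.

The compounds shown leave open how far either step truly reaches. They also leave open whether an amine or a carboxylic acid on this ring would give a number at all.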